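Pyrimidin-5-yl for pyridin-3-yl: the step to compound 3

The source may report more compounds than this note shows. Statements on the series, on what has been measured and on what is new or still open speak of the compounds shown alone.

Measured in a physicochemical assay for solubility, read by HPLC, in phosphate buffer, measured as kinetic solubility, at pH 2; a lower number here means a less soluble compound, a higher number a more soluble compound:
- compound 1 `COc1ccc(C(F)(F)F)cc1CN(C1CC1)C(c1cccnc1)c1nnnn1-c1ccccc1C`: 12.5 ug/mL
- compound 2 `Cc1ccccc1-n1nnnc1C(c1cccnc1)N(Cc1cccc(C(F)(F)F)c1)C1CC1`: 12 ug/mL

Within the data shown here, only two compounds have been measured so far, and compound 2, at 12 ug/mL, stands within the scatter of compound 1. Compound 3 `Cc1ccccc1-n1nnnc1C(c1cncnc1)N(Cc1cccc(C(F)(F)F)c1)C1CC1`, not yet measured, differs from compound 2 in a single group: pyrimidin-5-yl in place of pyridin-3-yl on a saturated chain carbon bound to an amine nitrogen and an aromatic carbon. Pyrimidin-5-yl takes the place of pyridin-3-yl on a saturated chain carbon bound to an amine nitrogen and an aromatic carbon.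

Among the measured compounds shown here, the one measured step, a 1.0-fold lower number from compound 1 to compound 2 (0.02 log units; within the scatter), puts hydrogen in place of methoxy on an aromatic carbon. It leaves pyridin-3-yl untouched, so it bears on this exchange only indirectly and shows no more than that compound 2 and compound 1 read alike. For the measured compounds named here, no measured step replaces pyridin-3-yl, and the data therefore give no direction. No change beyond the scatter is expected in this assay, although the uncertainty remains wide. The expected step is no change at the digits printed from compound 2 to compound 3 (within the scatter). Compound 3 is estimated at 12 ug/mL, with an expected range of 4 ug/mL to 36 ug/mL.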

Compound 3, solubility: 1.5 ug/mL
Compound 3: the middle estimate sits 8.0-fold (0.90 log units) above what was measured; measured number below the stated range.
By their numbers in this assay, from the lowest: compound 3; then compounds 2 and 1 (each within the scatter of the next).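

In this assay, the saturated chain carbon bound to an amine nitrogen and an aromatic carbon proves to be a place where a single exchange matters: pyrimidin-5-yl in place of pyridin-3-yl gives an 8.0-fold lower number from compound 2 to compound 3 (0.90 log units; beyond the scatter) in the read-out, whereas hydrogen in place of methoxy on an aromatic carbon had given only a 1.0-fold lower number from compound 1 to compound 2 (0.02 log units; within the scatter) and stayed within the scatter. Pyridin-3-yl and pyrimidin-5-yl each hold 6 heavy atoms and carry no net charge, so the step goes with a ring of 2 hetero atoms taking the place of a ring with 1 hetero atom, and it is the only change among the compounds shown that lies beyond the scatter. No measurement shown here accounts for the size of this step.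

Whether the lower number belongs to pyrimidin-5-yl alone or to other ring changes at this place stays open, since this is the only exchange shown there. An amine or a carboxylic acid carried on the pyridin-3-yl ring, or a plain phenyl ring in its place, would show whether the number can also rise at this position.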